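A few compounds are considered here, and "the series" means these few. Any claim that something is new, unique, unknown or untested is made for them only; others in the source may bear on it.

For the measured compounds named here, compound 2 `O=C1N(Cc2ccccc2Cl)c2cccn2S(=O)(=O)N1Cc1cccc(F)c1` is the only one of the three compounds that gives a plain number in an ADME assay on MT4 cells (Homo sapiens) for cytotoxicity, read by MTT assay, with a stated time of 5 days; a higher number here means that more compound is tolerated, a lower number that less compound is tolerated: compound 2 gives 231000 nM. Compound 1 `O=C1N(Cc2ccccc2)c2cccn2S(=O)(=O)N1Cc1cccc(F)c1` gives > 288000 nM, which is a limit of the assay and not a number. Compound 3 `O=C1N(Cc2ccccc2Cl)c2cccn2S(=O)(=O)N1Cc1ccccc1` likewise gives > 291000 nM, again a limit. The step from compound 2 to compound 4 `O=C1N(Cc2ccccc2Br)c2cccn2S(=O)(=O)N1Cc1cccc(F)c1` is bromo in place of chloro on an aromatic carbon. Going by the values given here, none of the measured steps makes this same exchange; the closest guidance comes from an at least 1.2-fold lower number from compound 1 to compound 2 (0.09 log units; that floor lies within the scatter) and from an at least 1.2-fold higher number from compound 2 to compound 3 (0.10 log units; that floor lies within the scatter), both of them small and at limits. Compound 4 is therefore expected to show a 1.0-fold lower number from compound 2 to compound 4 (0.00 log units; within the scatter), no shift beyond the scatter. The estimate for compound 4 is 230000 nM, ranging from 120000 nM to 300000 nM.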

Compound 4, half-maximal cytotoxic concentration: > 269000 nM
Compound 4: a limit, no number (the forecaster's own chance of this, stated with the estimate: 40%); at least 1.1-fold (0.06 log units) between middle value and limit.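

In this assay, the exchange of 2-chlorobenzyl for 2-bromobenzyl gives an at least 1.1-fold higher number from compound 2 to compound 4 (0.06 log units; that floor lies within the scatter). Compound 4 gives a limit of the assay and not a number: the limit of > 269000 nM in this assay, at which 1 of the 4 values shown sits. So bromo now joins chloro and hydrogen at this place on the ring without any shift beyond the scatter, while the step from compound 1 to compound 4 cannot be read, as both values are limits.

As far as these compounds go, how far the true value of compound 4 lies past its limit stays open. So does the outcome at this place for a methoxy group or an amine.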